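The compounds below may be only part of what the source reports. "The series", "measured", "known", "first", "only" and "open" are said of these compounds alone.

Working notes on the series, read in a physicochemical assay for lipophilicity, read by HPLC, at pH 7.5; a lower number here means a more polar compound, a higher number a more lipophilic compound. Among the compounds with values here, compound 1 `CCOc1ccccc1-c1ccc(-c2nc3cnccc3cc2C#N)cc1` gives 3.8, the highest number of the three measured so far. Compound 3 `CC[C@H](Nc1c(C#N)c(-c2ccc(Br)cc2)nc2cnccc12)C(N)=O` gives 2.3, the lowest of the three. Compound 2 `CC[C@@H](Nc1c(C#N)c(-c2ccc(-c3cccc(C)c3)cc2)nc2cnccc12)C(N)=O` gives 3 and so stands second highest. Its gaps to compound 3 below and to compound 1 above both lie beyond the usual scatter. Within the data shown here, these three compounds differ in more than one place, so no measured pair isolates a single structural change, and the data contain no direct guide to the size of the next step.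

Compound 4 `CC[C@@H](Nc1c(C#N)c(-c2ccc(-c3cccc(Cl)c3F)cc2)nc2cnccc12)C(N)=O` has 3-chloro-2-fluorophenyl in place of 3-methylphenyl on an aromatic carbon, para to a large group: 3-chloro-2-fluorophenyl in place of 3-methylphenyl on an aromatic carbon. The rest of the structure is shared with compound 2. The entering and leaving groups are each one six-membered aromatic ring of carbon only, with no net charge, so the expectation stays anchored on compound 2 at 3. The expected step of a number 0.20 log units higher from compound 2 to compound 4 (within the scatter) is small and upward, and it may not clear the scatter. For compound 4 the estimate is 3.2, with an expected range of 2.8 to 3.6.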

Compound 4, distribution coefficient: 3.1
Compound 4: the middle estimate sits 0.10 log units above what was measured, within the range that was stated.
By their numbers in this assay, from the lowest: compound 3; then compounds 2 and 4 (each within the scatter of the next); then compound 1.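

In this assay, within the data shown here, the only step that can be read in one place is a number 0.10 log units higher from compound 2 to compound 4 (within the scatter) and it gives the series its first direct reading at this position, on an aromatic carbon para to a large group. Replacing 3-methylphenyl with 3-chloro-2-fluorophenyl exchanges an all-carbon group of 7 heavy atoms for one of 8 heavy atoms carrying a fluorine and a chlorine, yet the two compounds cannot be told apart by this read-out, so this particular change leaves the number within the scatter. No measurement at hand bears on why the two compounds read alike.

The fluorine and the chlorine enter together, so the compounds shown do not separate them, and 3-chlorophenyl or 2-fluorophenyl alone would be needed to give each its own reading. On these data alone, whether a group of another kind at this same carbon, such as a piperazine, a morpholine or a carboxylic acid, would move the number beyond the scatter remains open, and steps involving compound 1 or compound 3 cannot be read because each differs from the others in more than one place.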